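Chloro for Hydrogen on the Cinnamic Acid Ring

The source may hold more compounds than are shown below. What is called first, only, known or untested is meant among the compounds shown, and "the series" means these compounds.

Measured so far in a functional assay on EA.hy 926 cells (Homo sapiens) for cytotoxicity, read by MTT assay, with stated times of 24 h and 12 h, tested at 25 uM; a lower number here means a weaker effect, a higher number a stronger effect of the compound at the concentration tested:
compound 1 `CCOC(=O)/C=C/c1cc(Cl)ccc1OC(=O)c1nc(C)c(C)nc1C`: 62.5%
compound 2 `Cc1nc(C)c(C(=O)Oc2ccccc2/C=C/C(=O)O)nc1C`: 61.8%
compound 3 `COc1ccc(/C=C/C(=O)O)c(OC(=O)c2nc(C)c(C)nc2C)c1`: -52.1%

Compound 2 stands second highest of the three numbers; compound 1 lies within the scatter of it, while compound 3 lies far below it, with the step of a number 113.9 percentage points lower from compound 2 to compound 3 (beyond the scatter). Compound 4 `Cc1nc(C)c(C(=O)Oc2ccc(Cl)cc2/C=C/C(=O)O)nc1C` differs from compound 2 by chloro in place of hydrogen on an aromatic carbon. Within the data shown here, no measured step shares this change: the only single-point step, from compound 2 to compound 3, concerns a methoxy group at another place, and compound 1 carries chloro but also an ethyl ester, so its number is not a step. Compound 4 is therefore expected to stay close to compound 2, with an estimated step of a number 1.8 percentage points lower from compound 2 to compound 4 (within the scatter) and an estimated value of 60%, ranging from 30% to 80%.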

Compound 4, a percentage reported as activity, at one concentration (the size of the read-out at that concentration, not a potency): 26%
For compound 4 the middle estimate is 34 percentage points above the measured one; the whole stated range lies above it.
By their numbers in this assay, from the lowest: compound 3; then compound 4; then compounds 2 and 1 (each within the scatter of the next).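

In this assay, the ring position para to a large group proves sensitive, with chloro in place of hydrogen giving a number 35.8 percentage points lower from compound 2 to compound 4 (beyond the scatter) on the acid. With chloro kept, hydrogen in place of ethyl on the oxygen next to a carbonyl group gives a number 36.5 percentage points lower from compound 1 to compound 4 (beyond the scatter) as a second large step, so the number for a chloro compound also depends on the ester. Nothing at hand explains either step. Going by these compounds, whether fluoro, methyl or an amine at this place would match chloro stays open, as does whether an amide in place of the ethyl ester would behave like it.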